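The source may hold more compounds than are shown below. What is called first, only, known or untested is meant among the compounds shown, and "the series" means these compounds.

Measured so far in an assay on isolated protein for inhibition of tyrosine-protein kinase receptor UFO (Homo sapiens), with a stated time of 1.5 h; a lower number here means a stronger inhibitor, a higher number a weaker inhibitor:
compound 1, `Cn1cc(-c2n[nH]c3ccc(NC4CCNC4)cc23)cn1`: 132000 nM
compound 2, `N#Cc1ccc(-n2cc(-c3n[nH]c4cc(Cl)c(N[C@@H]5CCNC5)cc34)cn2)cc1`: 700 nM
compound 3, `FC(F)(F)c1cccc2[nH]ncc12`: 184000 nM

Compound 1 stands second highest of the three numbers. Compound 3 lies within the scatter of compound 1, so the two cannot be separated. Compound 2 lies far lower than compound 1, well beyond the scatter. For the measured compounds named here, no two measured compounds differ in only one place, so no measured step is available to lean on.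

Compound 4, `Cn1cc(-c2n[nH]c3ccc(Nc4ccccc4)cc23)cn1`, is not yet measured in this assay. It differs from compound 1 by the following change:
phenyl in place of pyrrolidin-3-yl on a nitrogen on an aromatic ring
Nothing measured speaks to this change directly. The step expected is small, without a clear direction and not beyond the scatter: a 1.1-fold higher number from compound 1 to compound 4 (0.06 log units; within the scatter). Compound 4 is accordingly estimated at 150000 nM in this assay, expected to fall between 40000 nM and 500000 nM.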

Compound 4, half-maximal inhibitory concentration: 580 nM
For compound 4 the middle estimate is 260-fold (2.41 log units) above the measured one, and the stated range ends above it.
By their numbers in this assay, from the lowest: compounds 4 and 2 (each within the scatter of the next); then compounds 1 and 3 (each within the scatter of the next).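

In this assay, for the compounds shown here, the group on this nitrogen strongly sets the value: phenyl in place of pyrrolidin-3-yl gives a 230-fold lower number from compound 1 to compound 4 (2.36 log units; beyond the scatter), the first measured single-place step. The hydrogen-bond donor and acceptor counted on pyrrolidin-3-yl are therefore not needed for a low number on this core, since phenyl carries neither. No measurement at hand explains the step. From the compounds shown here alone, whether the gain follows from the aromatic ring or from the loss of the ring nitrogen remains open. Cyclopentyl would separate these two readings, while methoxyphenyl or pyridyl would test how much change the phenyl ring accepts.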